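This account rests on a few compounds, and the source may have more. Where it says the series, first, only, none or still open, it means among the compounds named here.

Three compounds have values in an ADME assay on cells (Erythrocyte, Homo sapiens), read by spectrophotometry and hemolysis, with a stated time of 24 h (on this read-out lower numbers stand for stronger inhibition and higher numbers for weaker inhibition), as follows:

Compound 1 `NC(=S)N/N=C/c1ccc(OCc2ccc3no[n+]([O-])c3c2)cc1` gives > 200 uM as a limit of the assay
Compound 2 `O=Cc1ccccc1OCc1ccc2no[n+]([O-])c2c1` gives > 100 uM as a limit of the assay
Compound 3 `CC1(C)[N+]([O-])=c2ccc(COc3ccc(C=O)cc3)cc2=[N+]1[O-]` gives 65 uM as a measured number

For the measured compounds named here, compound 3 holds the only number among the three, while the other two values are limits. The next compound, compound 4 `C=CCNC(=S)N/N=C/c1ccc(OCc2ccc3c(c2)=[N+]([O-])C(C)(C)[N+]=3[O-])cc1`, keeps the core of compound 3 and differs from it in one place, on an aromatic carbon of a six-membered aromatic ring of carbon only, para to a large group. The change is a group of 9 heavy atoms (5 carbon, 3 nitrogen, 1 sulfur; no ring) in place of a group of 2 heavy atoms (1 carbon, 1 oxygen; no ring), on an aromatic carbon and it removes the formyl. Going by the values given here, no measured pair shows this change on its own. The expectation leans on compound 1, which also carries a sulfur-bearing group and whose value of > 200 uM is a limit. A move towards weaker inhibition is therefore expected, estimated as a 2.3-fold higher number from compound 3 to compound 4 (0.36 log units; beyond the scatter) in this assay and only slightly beyond the usual scatter. The assay may well report only a limit here. For compound 4 the estimated value is 150 uM with an expected range from 60 uM to 300 uM in this hemolysis read-out.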

Compound 4, concentration for 50% inhibition: > 100 uM
Compound 4 was reported as a limit (the forecaster's own chance of this, stated with the estimate: 55%); the middle value lies beyond the limit too.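

For the compounds shown here, the step is the first reading at this position on the shared core: in this assay, putting the larger ring-free group in place of the formyl, on an aromatic carbon para to a large group, gives an at least 1.5-fold higher number from compound 3 to compound 4 (0.18 log units; that floor lies within the scatter). Compound 4 gives > 100 uM, which is a limit of the assay. The floor of the step lies within the scatter, so the data do not settle whether this change truly weakens inhibition, and the reading sits at a limit shared with another compound: the limit of > 100 uM in this assay, at which 2 of the 4 values shown sit.

On these data alone, whether a carboxylic acid or a primary amine at this place would give a measured number in this assay stays open. Also open, as far as these compounds go, is how much the formyl itself contributes to the measured value of compound 3, which is 65 uM.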